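Swapping 3-hydroxypropyl for isopropyl on a nitrogen

A few compounds are considered here, and "the series" means these few. Any claim that something is new, unique, unknown or untested is made for them only; others in the source may bear on it.

Results so far in an ADME assay on A549 cells (Homo sapiens) for cytotoxicity, read by LDH release, with a stated time of 15 h; on this read-out higher numbers stand for lower toxicity in this test and lower numbers for higher toxicity in this test 
- Compound 1 `O=C(Nc1ccc(NCc2cc(C(F)(F)F)cc(C(F)(F)F)c2)cc1Cl)c1cc(Cl)ccc1O` gives 22900 nM 
- Compound 2 `CC(C)(C)OC(=O)N1CCC(CNc2ccc(NC(=O)c3cc(Cl)ccc3O)c(Cl)c2)CC1` gives "not determined" (no result reported) 
- Compound 3 `O=C(Nc1ccc(NCCCO)cc1Cl)c1cc(Cl)ccc1O` gives "not determined" (no result reported) 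

Compound 3 has no single number, and neither does compound 2, so only compound 1 offers a measured value. Compound 4 `CC(C)Nc1ccc(NC(=O)c2cc(Cl)ccc2O)c(Cl)c1` has not yet been measured. It carries isopropyl in place of 3-hydroxypropyl on a nitrogen on an aromatic ring. Among the compounds with values here, no measured step shows what such a change does in this assay, so the expectation is no step beyond the scatter, in either direction. Within the data shown here, the only anchor is compound 1 at 22900 nM and the range is kept wide. Compound 4 is expected at 25000 nM (estimated range 8000 nM to 70000 nM).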

Compound 4, half-maximal cytotoxic concentration: 82700 nM
For compound 4 the middle estimate is 3.3-fold (0.52 log units) below the measured one; measured number outside the range, above it.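

Within the data shown here, with no single number for compound 3 in this assay no step to compound 4 can be read. The compounds shown leave open what isopropyl in place of 3-hydroxypropyl does on this read-out. No supporting evidence bears on this result.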